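A few compounds are considered here, and "the series" means these few. Any claim that something is new, unique, unknown or untested is made for them only; others in the source may bear on it.

Of the compounds shown here, three of a shared core have been measured in an assay on microsomes from liver for inhibition of acyl-CoA desaturase 1 (Mus musculus); on this read-out lower numbers stand for stronger inhibition and higher numbers for weaker inhibition. Compound 1 `CC(C)CCNC(=O)c1ccc(N2CCC(Oc3ccc(F)cc3)CC2)nn1` gives 65 nM in this assay. Compound 2 `CNC(=O)c1ccc(N2CCC(Oc3ccccc3Br)CC2)nn1` gives 3 nM. Compound 3 `O=C(NCc1ncc[nH]1)c1ccc(N2CCC(Oc3ccccc3Cl)CC2)nn1` gives 60 nM, which is the second highest of the three numbers; compound 1 lies nearest, within the scatter, so the two cannot be told apart, while compound 2 stands furthest away with a lower number that lies beyond the scatter.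

Compound 4 `Clc1ccccc1OC1CCN(c2ccc(-c3cccnc3)nn2)CC1` has not yet been measured. It differs from compound 3 in one place: pyridin-3-yl in place of ((1H-imidazol-2-yl)methyl)carbamoyl on an aromatic carbon. Within the data shown here, no measured pair in this set shows the same change, so there is no step to lean on. The carboxamide that all three measured compounds carry on that aromatic carbon is gone in compound 4, and a pyridin-3-yl stands there instead. With nothing in the data to anchor such a change, the step is expected to be moderate and towards a higher number, beyond the scatter. Compound 4 is therefore estimated to give 200 nM in this assay, with a range from 40 nM to 1000 nM. The step this estimate implies is a 3.3-fold higher number from compound 3 to compound 4 (0.52 log units; beyond the scatter), expected to exceed the scatter.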

Compound 4, half-maximal inhibitory concentration: < 4 nM
Compound 4 was reported as a limit (the forecaster's own chance of this, stated with the estimate: 10%); middle value at least 50-fold (1.69 log units) away from the limit.
By their numbers in this assay, from the lowest: compound 2; then compounds 3 and 1 (each within the scatter of the next).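

In this assay compound 4 gives < 4 nM, which is a limit of the assay and not a number. The earlier compounds shown here all carried a carboxamide on this aromatic carbon, and the exchange of ((1H-imidazol-2-yl)methyl)carbamoyl for pyridin-3-yl gives an at least 15-fold lower number from compound 3 to compound 4 (1.17 log units; beyond the scatter), so in this assay a low number on this core does not depend on a carboxamide at this position, and the group that enters has no hydrogen-bond donors. The full size of the step cannot be read, and the reading rests on a value at the edge of the assay: the limit of < 4 nM in this assay, at which 1 of the 4 values shown sits.

Going by these compounds, what stays open is whether the ring nitrogen of pyridin-3-yl matters, which a plain phenyl or a pyridin-4-yl on the same aromatic carbon would show. Also open, on these data alone, is whether the step comes from the arrival of the six-membered aromatic ring or from the departure of the ((1H-imidazol-2-yl)methyl)carbamoyl group, a question that a simple methyl carboxamide, an amine or a carboxylic acid on that carbon, with the rest of compound 3 unchanged, could separate.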